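From 2-chlorophenyl to 4-chlorophenyl: what to expect

A few compounds are considered here, and "the series" means these few. Any claim that something is new, unique, unknown or untested is made for them only; others in the source may bear on it.

Compound 1 `Cc1ccccc1CNC(=O)/C=C/c1ccc(O)c(O)c1` gives 20000 nM
Compound 2 `O=C(/C=C/c1ccc(O)c(O)c1)NCc1ccccc1Cl` gives 6500 nM

In a functional assay on B16 cells (Mus musculus) for inhibition (on this read-out lower numbers stand for stronger inhibition and higher numbers for weaker inhibition), compound 2 holds the lower of the two numbers, 6500 nM and so far the stronger result. Compound 3 `O=C(/C=C/c1ccc(O)c(O)c1)NCc1ccc(Cl)cc1` has the same atoms joined differently, and 4-chlorophenyl in place of 2-chlorophenyl on a saturated chain carbon bound to an amide-type nitrogen is the whole change. For the measured compounds named here, only one measured step bears on it, a 3.1-fold lower number from compound 1 to compound 2 (0.49 log units; beyond the scatter) and that step swaps one group for another without moving any group. It therefore gives no direction for this change, and no step beyond the scatter is expected in this assay. The expected step is a 1.1-fold higher number from compound 2 to compound 3 (0.03 log units; within the scatter) on this estimate. Compound 3 is estimated at 7000 nM with an expected range from 2500 nM to 20000 nM in this assay.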

Compound 3, half-maximal inhibitory concentration: 1800 nM
The estimate for compound 3 lay 3.9-fold (0.59 log units) above the measured number; the measured number lies below the stated range.
By their numbers in this assay, from the lowest: compound 3; then compound 2; then compound 1.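

With the same atoms joined differently, this assay shows a 3.6-fold lower number from compound 2 to compound 3 (0.56 log units; beyond the scatter), so on this benzyl-type chain carbon the place of the chlorine on the aromatic ring matters, and not only which group is present. Compound 3 also carries the largest gap so far, with an 11-fold lower number from compound 1 to compound 3 (1.05 log units; beyond the scatter), although that comparison changes both the group and its place. Nothing available explains why the 4-chlorophenyl group gives the lower number. Still open, from the compounds shown here alone, is whether 4-methylphenyl would improve on the 2-methylphenyl of compound 1 in the same way, which would show if the effect of place extends beyond chlorine. Also open, going by these compounds, is how 4-bromophenyl or 4-methoxyphenyl would compare with 4-chlorophenyl.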